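Bromo for fluoro on the anilino ring: compound 4

A few compounds are considered here, and "the series" means these few. Any claim that something is new, unique, unknown or untested is made for them only; others in the source may bear on it.

The series shares the core of compound 1 `Fc1ccc2nc(-c3ccccc3)nc(Nc3ccccc3)c2c1`; in a functional assay on U-937 cells (Homo sapiens) for cytotoxicity, read by MTT assay, with a stated time of 48 h (a higher number here means a weaker inhibitor, a lower number a stronger inhibitor), compound 1 gives > 50000 nM, which is a limit of the assay. Compound 2 `Fc1cccc(-c2nc(Nc3ccccc3)c3cc(F)ccc3n2)c1` gives 45500 nM in this assay. Compound 3 `Fc1ccc(Nc2nc(-c3cccc(F)c3)nc3ccc(F)cc23)cc1` gives > 50000 nM, again a limit. Compound 4 `Fc1cccc(-c2nc(Nc3ccc(Br)cc3)c3cc(F)ccc3n2)c1` differs from compound 3 by bromo in place of fluoro on an aromatic carbon. Within the data shown here, no measured step swaps one halogen for another; the nearest guides are an at least 1.0-fold lower number from compound 1 to compound 2 (0.04 log units; that floor lies within the scatter) and an at least 1.0-fold higher number from compound 2 to compound 3 (0.04 log units; that floor lies within the scatter), both within the scatter, and (the limit of > 50000 nM in this assay, at which 2 of the 3 values shown sit). For compound 4 the expected step is therefore a number no higher from compound 3 to compound 4 (the limit leaves the size open), nothing beyond the scatter. The estimate for compound 4 in this assay is 50000 nM, within 20000 nM to 150000 nM, most likely reported as a limit again.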

Compound 4, half-maximal inhibitory concentration: > 50000 nM
Compound 4: no number, only a limit; the forecaster's own chance of this, stated with the estimate: 70%; the middle value lies on the limit itself.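

Among these compounds, the first halogen exchange at this position, 4-fluorophenyl to 4-bromophenyl, cannot be read as a step, as compound 3 and compound 4 both stand at limits. Among the compounds shown here, the one readable comparison is an at least 1.0-fold higher number from compound 2 to compound 4 (0.04 log units; that floor lies within the scatter), so bromo on this aromatic carbon, like fluoro, brings no lower number. Only compound 2 has a number, and the others sit at one ceiling in this assay: the limit of > 50000 nM in this assay, at which 3 of the 4 values shown sit.

Left open is whether an amine or a carboxylic acid in place of bromo on this aromatic carbon would bring a value off the limit. From the compounds shown here alone, how far compound 3 and compound 4 lie beyond the limit also stays unknown.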